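Arylamino swap on the shared core, step to compound 3

This account rests on a few compounds, and the source may have more. Where it says the series, first, only, none or still open, it means among the compounds named here.

Compound 1 `CCS(=O)(=O)Nc1cc(-c2ccc3ncnc(Nc4ccc(OC(F)(F)F)cc4)c3c2)cnc1OC` has been tested in a functional assay on MCF7 cells (Homo sapiens) for cytotoxicity, read by sulforhodamine B assay, with a stated time of 72 h (on this read-out lower numbers stand for stronger inhibition and higher numbers for weaker inhibition), where compound 1 gives 23700 nM. Compound 2 `CCCCS(=O)(=O)Nc1cc(-c2ccc3ncnc(Nc4cccc(C(=O)OCC)c4)c3c2)cnc1OC` differs from compound 1 in several places. In this assay compound 2 gives 36400 nM. Compound 1 has the lower of the two numbers, but the gap to compound 2 lies within the scatter, so no order between them is claimed. Compound 3 `CCS(=O)(=O)Nc1cc(-c2ccc3ncnc(Nc4ccc(F)nc4)c3c2)cnc1OC` has not yet been measured. It differs from compound 1 in a single place: 6-fluoropyridin-3-yl in place of 4-(trifluoromethoxy)phenyl on a nitrogen on an aromatic ring. Within the data shown here, no measured pair isolates this change, so no step beyond the scatter is expected in either direction in this assay; the expected step from compound 1 is a 1.3-fold higher number from compound 1 to compound 3 (0.10 log units; within the scatter). Compound 3 is therefore estimated to give about 30000 nM in this assay, with a range from 8000 nM to 120000 nM.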

Compound 3, half-maximal inhibitory concentration: 5390 nM
Compound 3: the middle estimate sits 5.6-fold (0.75 log units) above what was measured; measured number outside the range, below it.
By their numbers in this assay, from the lowest: compound 3; then compounds 1 and 2 (each within the scatter of the next).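

Among these compounds, at the place on a nitrogen on an aromatic ring, this change gives the first step in this assay that lies beyond the scatter: a 4.4-fold lower number from compound 1 to compound 3 (0.64 log units; beyond the scatter). The group at this place therefore moves the read-out, and in this pair the lower number goes with 6-fluoropyridin-3-yl, the group with fewer heavy atoms and one hetero atom in its ring. Nothing at hand bears on why the step occurs.

Open, on these data alone, is whether the ring nitrogen or the fluorine carries the step, a question that 4-fluorophenyl or unsubstituted pyridin-3-yl on the same nitrogen would separate. Also open, as far as these compounds go, is how an amine or a carboxylic acid in place of the fluorine would read in this assay.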